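Chloro to Hydroxy on the Aniline Ring of Compound 1

The compounds below may be only part of what the source reports. "The series", "measured", "known", "first", "only" and "open" are said of these compounds alone.

Measured so far:
compound 1 `Clc1ccccc1Nc1nc(-c2ccncc2)cs1`: 28200 nM
compound 2 `CC(C)(C)c1cccc(Nc2nc(-c3ccncc3)cs2)c1`: 60300 nM
compound 3 `Cc1cccc(Nc2nc(-c3ccnc(-c4cccc5[nH]ccc45)c3)cs2)c1`: 3100 nM; 3160 nM (2 entries)

In a functional assay on RCC4 cells (Homo sapiens) for inhibition, read by XTT assay, with a stated time of 4 days (a lower number here means a stronger inhibitor, a higher number a weaker inhibitor), compound 1 gives 28200 nM, the lower of the two single numbers shown; compound 2 gives 60300 nM, a higher number that lies beyond the usual scatter. Compound 3 has several entries, (the several entries of compound 3 in this assay, 3100 nM; 3160 nM (2 entries)), rather than one number.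

Compound 4 `Oc1ccccc1Nc1nc(-c2ccncc2)cs1` is the unmeasured partner of compound 1. The change is hydroxy in place of chloro on an aromatic carbon.

Among the compounds with values here, no pair of measured compounds differs only in this way, so nothing here shows how this change shifts the number. Compound 4 is expected to stay close to compound 1, with a step of a 1.1-fold higher number from compound 1 to compound 4 (0.03 log units; within the scatter) that is expected to remain within the scatter. The estimate for compound 4 in this assay is 30000 nM, in the range 8000 nM to 120000 nM.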

Compound 4, half-maximal inhibitory concentration: 12900 nM
Estimate against measurement, compound 4: 2.3-fold (0.37 log units) above; measured number inside the range.
By their numbers in this assay, from the lowest: compound 4; then compound 1; then compound 2.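

In this assay, hydroxy in place of chloro on this aromatic carbon, ortho to a large group, gives a 2.2-fold lower number from compound 1 to compound 4 (0.34 log units; beyond the scatter). Within the data shown here, this is the first step read at this position, and it shows that the chloro can be replaced without a loss, with a modest gain instead. Nothing measured here explains why the number falls. From the compounds shown here alone, it remains open whether an amine or a methoxy group at the same place would lower the number further. Going by these compounds, it is also open whether the same change would give a similar step on the core of compound 3.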